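Lengthening the acetyl group of compound 2

This account rests on a few compounds, and the source may have more. Where it says the series, first, only, none or still open, it means among the compounds named here.

For the measured compounds named here, in a physicochemical assay for solubility, using the shake flask method, in phosphate buffer, with a stated time of 24 h, at 37 degrees C, at pH 6.8 (a lower number here means a less soluble compound, a higher number a more soluble compound), compound 1 (`CCCc1nc(O)c2c[nH]nc2n1`) gives 2560 ug/mL as the only exact number so far. For compound 2 (`CC(=O)n1ncc2c(=O)[nH]cnc21`) there is only a limit, > 65 ug/mL and not a number. Compound 2 therefore stands with its true value unknown. Going by the values given here, compound 1 and compound 2 differ in more than one place, so no measured step bears on the change followed here.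

Compound 3 (`CCCC(=O)n1ncc2c(=O)[nH]cnc21`) keeps the shared core of compound 2 and carries ethyl in place of hydrogen on a saturated chain carbon bound to a carbonyl carbon, so that acetyl becomes propylcarbonyl. With nothing measured to scale this change, a moderate fall is expected in this assay and its size remains uncertain. The expected change, an at least 1.3-fold lower number from compound 2 to compound 3 (0.11 log units; that floor lies within the scatter) as estimated here, starts from a limit and should be read loosely. Compound 3 is estimated at 50 ug/mL in this assay with an expected range from 10 ug/mL to 250 ug/mL and could also return only a limit.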

Compound 3, solubility: > 65 ug/mL
Compound 3: no number, only a limit; the forecaster's own chance of this, stated with the estimate: 35%; middle value at least 1.3-fold (0.11 log units) away from the limit.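

Compound 3 returns only a limit in this assay, as compound 2 does, so no step can be read between the two compounds: the limit of > 65 ug/mL in this assay, at which 2 of the 3 values shown sit.

The compounds shown leave open how far the true values of compound 2 and compound 3 lie from that limit, and whether lengthening acetyl to propylcarbonyl moves the read-out at all.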